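This account rests on a few compounds, and the source may have more. Where it says the series, first, only, none or still open, it means among the compounds named here.

Working notes on the series. In a functional assay on HL-60 cells (Homo sapiens) for cytotoxicity, read by MTT assay, with a stated time of 72 h (a higher number here means a weaker inhibitor, a lower number a stronger inhibitor), compound 1 (`O=C(COc1ccccc1)Nc1nnc(-c2cccc(O)c2O)s1`) gives 11200 nM, compound 2 (`Cc1ccc(C(=O)Nc2nnc(-c3ccc(O)c(O)c3)s2)cc1`) gives 10500 nM and compound 3 (`O=C(COc1ccccc1)Nc1nnc(-c2ccc(O)c(O)c2)s1`) gives 17400 nM. Compound 3 therefore stands within the scatter of both other compounds, as the two measured steps show: a 1.6-fold higher number from compound 1 to compound 3 (0.19 log units; within the scatter) and a 1.7-fold higher number from compound 2 to compound 3 (0.22 log units; within the scatter).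

The change now in view leads to compound 4 (`O=C(Nc1nnc(-c2ccc(O)c(O)c2)s1)C1CCCCC1`), with cyclohexyl in place of phenoxymethyl on a carbonyl carbon.

For the measured compounds named here, the closest precedent is a 1.7-fold higher number from compound 2 to compound 3 (0.22 log units; within the scatter), a replacement on the same carbonyl carbon that stays within the scatter. The other step, a 1.6-fold higher number from compound 1 to compound 3 (0.19 log units; within the scatter), concerns an aromatic carbon and bears on the new change only as a measure of how flat the series has been so far. Going by the values given here, no measured compound carries cyclohexyl, so this precedent is indirect and the direction of any step remains open. In this assay, no step beyond the scatter is expected.

The estimate is placed near the centre of the three measured values. The expected change is a 1.3-fold lower number from compound 3 to compound 4 (0.13 log units; within the scatter), which is an estimate and not a measured step. For compound 4, the estimated value is 13000 nM, with an expected range from 6000 nM to 28000 nM.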

Compound 4, half-maximal inhibitory concentration: 8800 nM
Beside the measured number, compound 4's estimate is 1.5-fold (0.17 log units) above it, within the range that was stated.
By their numbers in this assay, from the lowest: compounds 4, 2, 1 and 3 (each within the scatter of the next).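

Cyclohexyl is the first group at this carbonyl carbon without an aromatic ring, and the oxygen of phenoxymethyl goes with the exchange, yet a 2.0-fold lower number from compound 3 to compound 4 (0.30 log units; within the scatter), which stays within the scatter in this assay. The same holds against the other aromatic group at this place, with a 1.2-fold lower number from compound 2 to compound 4 (0.08 log units; within the scatter), so phenoxymethyl, 4-methylphenyl and cyclohexyl on the carbonyl carbon all give numbers that cannot be told apart in the pairs read here, and an aromatic ring in this group is not needed to keep the number in this range. Nothing at hand explains why the numbers stay together across these three groups.

Still open is whether an amine, a carboxylic acid or a longer alkyl chain on this carbonyl carbon would give a step beyond the scatter, given that the three groups shown are all built around a six-membered ring of carbon only. Also open, as far as these compounds go, is whether cyclohexyl keeps the same standing when the 3,4-dihydroxyphenyl group is exchanged for the 2,3-dihydroxyphenyl group of compound 1.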